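Fluoro to Methoxy Swap on a Shared Pyrazole Core

A few compounds are considered here, and "the series" means these few. Any claim that something is new, unique, unknown or untested is made for them only; others in the source may bear on it.

Compound 1 `Fc1ccc(-c2cc(-c3ccc4cc(F)ccc4n3)nn2-c2ccccc2)cc1` and compound 2 `COc1ccc(-c2cc(-c3ccc4cc(F)ccc4n3)nn2-c2ccccc2)cc1` share one core and differ in a single place: methoxy in place of fluoro on an aromatic carbon. In an ADME assay on Huh-7 cells (Homo sapiens) for cytotoxicity, read by XTT assay, with a stated time of 3 days, tested at 20 uM (on this read-out lower numbers stand for a stronger effect and higher numbers for a weaker effect at the one concentration tested), compound 1 gives 88.3%, and compound 2 gives 95.6%. That step, a number 7.3 percentage points higher from compound 1 to compound 2 (within the scatter), is small. Compound 3 `Fc1ccc(-c2cc(-c3ccc4cc(F)ccc4n3)n(-c3ccc(F)cc3)n2)cc1` has a different core; how its core differs from that of compound 1 is not broken down here. In this assay compound 3 gives 95.3%. Compound 4 `COc1ccc(-c2cc(-c3ccc4cc(F)ccc4n3)n(-c3ccc(F)cc3)n2)cc1` has not yet been measured; it differs from compound 3 by methoxy in place of fluoro on an aromatic carbon, the same change seen before. Because the earlier step of a number 7.3 percentage points higher from compound 1 to compound 2 (within the scatter) stayed within the scatter, a step of similar size is expected now, a number 2.7 percentage points higher from compound 3 to compound 4 (within the scatter). Compound 4 is therefore estimated at 98%, expected between 88% and 106%.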

Compound 4, a percentage reported as activity, at one concentration (the size of the read-out at that concentration, not a potency): 98.8%
Beside the measured number, compound 4's estimate is 0.8 percentage points below it; measured number inside the range.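

In this assay, the swap from 4-fluorophenyl to 4-methoxyphenyl on the second core gives a number 3.5 percentage points higher from compound 3 to compound 4 (within the scatter). Set beside the earlier step, the two cores show no difference that can be told from scatter: the same change on two cores in this assay, a number 7.3 percentage points higher (within the scatter) from compound 1 to compound 2 and a number 3.5 percentage points higher (within the scatter) from compound 3 to compound 4, 3.8 percentage points apart, within the scatter of two such steps. This shows that the swap behaves alike on these two cores in this one read-out at one concentration, but it does not show that the swap has any real effect here, nor that it would behave the same way on other cores or in other assays.

The compounds shown leave open how an amine or a carboxylic acid at that same place would read in this assay. They also leave open whether a longer chain on the oxygen, such as ethoxy, would stay within the scatter.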